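Estimating compound 4 without a value for compound 3

The compounds below may be only part of what the source reports. "The series", "measured", "known", "first", "only" and "open" are said of these compounds alone.

- compound 1 `COC1=C(C)C(=O)/C(=C(O)/C=C/c2ccc(Br)cc2)C(=O)C1(C)C`: 1.1 ug/mL
- compound 2 `COC1=C(C)C(=O)/C(=C(O)/C=C/c2ccccc2OC)C(=O)C1(C)C`: 2.5 ug/mL
- compound 3 `COC1=C(C)C(=O)/C(=C(O)/C=C/c2ccccc2C)C(=O)C1(C)C`: "not determined" (no result reported)

In a functional assay on 1A9 cells (Homo sapiens) for cytotoxicity (on this read-out higher numbers stand for an effect only at larger amounts of compound and lower numbers for an effect already at smaller amounts), compound 3 has no single number: its result is "not determined" (no result reported). The step to compound 4 `CCc1ccc(/C=C/C(O)=C2/C(=O)C(C)=C(OC)C(C)(C)C2=O)cc1` therefore has no measured starting point. The structural change is 4-ethylphenyl in place of 2-methylphenyl on a double-bonded chain carbon bound to a double-bonded chain carbon. Within the data shown here, the one measured step that bears on this change is a 2.3-fold higher number from compound 1 to compound 2 (0.36 log units; beyond the scatter). That step is modest but beyond the usual scatter, and it also swaps one substituted phenyl group for another on the same chain carbon. No size or direction can be expected for the step from compound 3, so the estimate must rest on the two measured neighbours. The 4-ethylphenyl group of compound 4 carries its substituent at the same numbered ring carbon as the 4-bromophenyl group of compound 1, which gives 1.1 ug/mL, so the estimate leans modestly towards that value. Two measured compounds make a thin basis, so the expected range is wide. Compound 4 is expected to give about 1.6 ug/mL, with an estimated range from 0.6 ug/mL to 4 ug/mL.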

Compound 4, concentration for half-maximal effect: 5.3 ug/mL
Estimate against measurement, compound 4: 3.3-fold (0.52 log units) below; the measured number lies above the stated range.
By their numbers in this assay, from the lowest: compound 1; then compound 2; then compound 4.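

In this assay, putting ethyl in place of bromo on the aromatic carbon gives a 4.8-fold higher number from compound 1 to compound 4 (0.68 log units; beyond the scatter), so the shared number in the names 4-bromophenyl and 4-ethylphenyl does not by itself keep two compounds close on this read-out. What the substituent is therefore counts here, not only the ring carbon that carries it. The 4-ethylphenyl group in place of 2-methoxyphenyl on the same chain carbon gives a 2.1-fold higher number from compound 2 to compound 4 (0.33 log units; beyond the scatter), which leaves compound 4 with the highest number of the three measured compounds, while no measurement shown explains these differences.

Going by these compounds, the step from compound 3 to compound 4 cannot be read, as compound 3 has no reported result, so the effect of the 2-methylphenyl group remains unknown. Also open, on these data alone, is where an unsubstituted phenyl group, or a phenyl group carrying an amine or a carboxylic acid, would fall on this read-out.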